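Turning two stereocentres of compound 3

The source may hold more compounds than are shown below. What is called first, only, known or untested is meant among the compounds shown, and "the series" means these compounds.

Compound 1 `CCCCCCCCCCCCCC[C@H]1N[C@H](CO)[C@H]1O` gives 6 ug/mL
Compound 2 `CC(C)CC[C@H](O)CCCCCCCCC[C@@H]1N[C@@H](CO)[C@@H]1O` gives > 10 ug/mL as a limit of the assay, not a number
Compound 3 `CCCCCCCCCCCCCC[C@@H]1N[C@@H](CO)[C@@H]1O` gives 3.4 ug/mL

All three results come from a functional assay on KB cells (Homo sapiens) for cytotoxicity; a lower number here means a stronger inhibitor, a higher number a weaker inhibitor. Compound 3 is the mirror image of compound 1, and the two stay within the scatter of each other, as the step shows: a 1.8-fold lower number from compound 1 to compound 3 (0.25 log units; within the scatter). The only other result is the limit of compound 2, and the step to it is an at least 2.9-fold lower number from compound 2 to compound 3 (0.46 log units; beyond the scatter). That step concerns the chain, which stays the same in the change considered here, so it offers little guidance.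

The unmeasured compound 4 `CCCCCCCCCCCCCC[C@@H]1N[C@H](CO)[C@H]1O` keeps the atoms and bonds of compound 3, with nothing leaving and nothing entering. Only the drawn configuration changes: the two compounds have the same atoms and bonds and differ only in configuration as drawn: 2 of 3 stereo elements differ; a stereocentre at a saturated ring carbon is drawn S in compound 3 and R in compound 4; a stereocentre at a saturated ring carbon is drawn R in compound 3 and S in compound 4.

The closest guide is therefore the mirror-image pair, where inverting all stereocentres gave only a 1.8-fold lower number from compound 1 to compound 3 (0.25 log units; within the scatter). Going by the values given here, compound 4 is not a mirror image of either compound, however, and no measured pair shows a partial inversion, so the range has to stay wide. No shift beyond the scatter is expected, and the expected step is a 1.5-fold higher number from compound 3 to compound 4 (0.17 log units; within the scatter) in this assay.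

For compound 4 the estimated value is 5 ug/mL, with an expected range of 2 ug/mL to 12 ug/mL and some chance of a limit instead of a number.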

Compound 4, half-maximal inhibitory concentration: > 10 ug/mL
Compound 4: no number, only a limit; the forecaster's own chance of this, stated with the estimate: 15%; at least 2.0-fold (0.30 log units) between middle value and limit.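

In this assay the partial inversion gives an at least 2.9-fold higher number from compound 3 to compound 4 (0.46 log units; beyond the scatter), whereas full inversion in the mirror-image pair, compound 1 and compound 3, stayed within the scatter. From the compounds shown here alone, compound 4 gives > 10 ug/mL, which is a limit of the assay and not a number, so the full size of this shift remains unknown. The result shows that the outcome depends on which stereocentres are inverted, not only on how many, and the shift can be traced to configuration alone because no atom or bond changes: the fact that compounds 3 and 4 differ only in the configuration as drawn

Going by these compounds, the remaining comparison, an at least 1.6-fold higher number from compound 1 to compound 4 (0.22 log units; that floor lies within the scatter), has a floor that cannot be separated from the scatter, so the effect of inverting that single stereocentre stays open. On these data alone, it also remains unknown whether the same dependence on configuration would hold with a longer chain on the shared core, or with an amine or a carboxylic acid added to it.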